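The source may hold more compounds than are shown below. What is called first, only, known or untested is meant among the compounds shown, and "the series" means these compounds.

For the measured compounds named here, compound 1 `CC(C)(C)n1ncc(OCc2nnc(-c3ccc(Br)cc3)o2)c(Cl)c1=O` is the one compound here for which this study yields a number: in a functional assay on the whole organism for inhibition, with Mythimna separata as the target, with a stated time of 5 days (a higher number here means that more compound is needed for the effect, a lower number that less compound is needed), compound 1 gives 21400 nM. Compound 2 `Cc1cc(C)cc(-c2nnc(COc3cnn(C(C)(C)C)c(=O)c3Cl)s2)c1` carries a 3,5-dimethylphenyl group on a core whose five-membered ring holds sulfur rather than oxygen. For compound 2 this assay returns only a limit, > 299000 nM, and no number. Compound 2 therefore stands at the limit of > 299000 nM in this assay, at which 1 of the 2 values shown sits.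

Compound 3 `CC(C)(C)n1ncc(OCc2nnc(-c3ccc(F)cc3)s2)c(Cl)c1=O` differs from compound 2 in a single place: 4-fluorophenyl in place of 3,5-dimethylphenyl on an aromatic carbon. Going by the values given here, the two measured compounds differ in more than one place, so no single step between them is isolated, and the only number available is that of compound 1 with its 4-bromophenyl group, 21400 nM. Because compound 2 only reaches > 299000 nM, the size of the step to compound 3 cannot be fixed from the data; the expectation is a move toward lower values, as expressed by the estimated step of an at least 4.9-fold lower number from compound 2 to compound 3 (0.69 log units; beyond the scatter). Compound 3 is thus expected to give about 60000 nM, within a range from 15000 nM to 299000 nM.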

Compound 3, half-maximal effective concentration: 21500 nM
Compound 3: middle estimate off by 2.8-fold (0.45 log units), on the high side; measured number inside the range.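

For the compounds shown here, at this position, on an aromatic carbon of a five-membered aromatic ring with 2 nitrogen and 1 sulfur, the choice of aryl group proves decisive: in this assay, 4-fluorophenyl in place of 3,5-dimethylphenyl gives an at least 13-fold lower number from compound 2 to compound 3 (1.14 log units; beyond the scatter), the first single-place step and a large one. Compound 3 carries the same sulfur-containing core as compound 2 yet returns a real number, so this core alone does not hold a compound at the limit of the assay. As far as these compounds go, the true size of the step remains unknown because compound 2 gives only a limit and not a number: the limit of > 299000 nM in this assay, at which 1 of the 3 values shown sits.

Going by these compounds alone, the single exchange does not separate the loss of the two methyl groups from the entry of the fluorine, and compound 1 and compound 3 differ in more than one place, so the effect of sulfur against oxygen in the five-membered ring is not isolated. From the compounds shown here alone, it also remains open how a plain phenyl, or a phenyl carrying a methoxy group or a nitrile, would behave at this position.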